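Amide series: isopropyl in place of propyl

The source may report more compounds than this note shows. Statements on the series, on what has been measured and on what is new or still open speak of the compounds shown alone.

Values so far come from an assay on SHEP1 cells for agonist activity at Neuronal acetylcholine receptor; alpha4/beta2 (Homo sapiens), read by FLIPR and calcium flux; a higher number here means that more compound is needed for the effect, a lower number that less compound is needed:
- compound 1, `O=C(C1CC1)[C@H]1C[C@@H]2CNC[C@@H](C2)C1`: 7100 nM
- compound 2, `CCCNC(=O)[C@H]1C[C@@H]2CNC[C@@H](C2)C1`: 2400 nM

Within the data shown here, compound 2 stands lowest of the two numbers; the single recorded step, a 3.0-fold lower number from compound 1 to compound 2 (0.47 log units; beyond the scatter), separates it from compound 1, which is its only neighbour in the set.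

Compound 3, `CC(C)NC(=O)[C@H]1C[C@@H]2CNC[C@@H](C2)C1`, is not yet measured. It differs from compound 2 by isopropyl in place of propyl on an amide-type nitrogen. Among the measured compounds shown here, no measured step bears directly on this change: the one step in hand, a 3.0-fold lower number from compound 1 to compound 2 (0.47 log units; beyond the scatter), swaps the group on the carbonyl carbon rather than rearranging a chain on the amide-type nitrogen, and even that step was only modest. For the measured compounds named here, with the same atoms joined differently and no precedent for chain branching, the step expected here, a 1.0-fold higher number from compound 2 to compound 3 (0.02 log units; within the scatter), lies within the scatter. Compound 3 is accordingly estimated at 2500 nM, with a range of 900 nM to 7000 nM; the range is kept wide because a 3.0-fold lower number from compound 1 to compound 2 (0.47 log units; beyond the scatter) shows that changes around the carbonyl are not inert in this assay.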

Compound 3, half-maximal effective concentration: 1900 nM
Estimate against measurement, compound 3: 1.3-fold (0.12 log units) above; measured number inside the range.
By their numbers in this assay, from the lowest: compounds 3 and 2 (each within the scatter of the next); then compound 1.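

In this assay, rearranging the propyl chain on the amide-type nitrogen into isopropyl gives a 1.3-fold lower number from compound 2 to compound 3 (0.10 log units; within the scatter) and so does not separate the two arrangements of the chain, which makes this the first sign that branching at this position is tolerated. The step of a 3.7-fold lower number from compound 1 to compound 3 (0.57 log units; beyond the scatter) lies beyond the scatter, as does a 3.0-fold lower number from compound 1 to compound 2 (0.47 log units; beyond the scatter), so both the propylamino and isopropylamino groups on the carbonyl carbon keep the same modest separation from the cyclopropyl group of compound 1. Nothing available accounts for either the separation or the lack of one.

Still open, from the compounds shown here alone, is whether this tolerance on the amide-type nitrogen extends to a bulkier tert-butyl group, a longer chain such as pentyl, or an aromatic benzyl group. The compounds shown also leave open what happens when the amide hydrogen itself is replaced, for example by a methyl group, since all the amides here keep that hydrogen.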